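Aryl swap on the core: compound 3 to compound 4

This account rests on a few compounds, and the source may have more. Where it says the series, first, only, none or still open, it means among the compounds named here.

Compound 3 `CCCCCCCCS(=O)(=O)Nc1ccc(-c2cccc(Cl)c2)cc1C(=O)O` gives 8900 nM in an assay on mitochondria (strain BALB/c) for inhibition of glycerol-3-phosphate acyltransferase 1, mitochondrial (Mus musculus), read by scintillation counting, with a stated time of 10 min (a higher number here means a weaker inhibitor, a lower number a stronger inhibitor), the lowest number of the three measured, but within the scatter of compound 1 `CCCCCCCCS(=O)(=O)Nc1cc(-c2ccc(OC)cc2)ccc1C(=O)O`, which gives 13300 nM; compound 2 `CCCCCCCCS(=O)(=O)Nc1cc(-c2ccc(O)cc2)ccc1C(=O)O` gives 64800 nM. Going by the values given here, the one measured step, a 4.9-fold higher number from compound 1 to compound 2 (0.69 log units; beyond the scatter), concerns hydrogen in place of methyl on an oxygen and does not touch the change now proposed. Compound 4 `CCCCCCCCS(=O)(=O)Nc1ccc(-c2ccc(OC)cc2)cc1C(=O)O` carries 4-methoxyphenyl in place of 3-chlorophenyl on an aromatic carbon. Among the compounds with values here, no measured step bears on this exchange; the only guide is that compound 1, also bearing a 4-methoxyphenyl group, sits within the scatter of compound 3. Compound 4 is therefore expected to show a 1.3-fold higher number from compound 3 to compound 4 (0.13 log units; within the scatter), a step not beyond the scatter, with an estimate of 12000 nM and a range of 5000 nM to 30000 nM.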

Compound 4, half-maximal inhibitory concentration: 19500 nM
For compound 4 the middle estimate is 1.6-fold (0.21 log units) below the measured one; the measured number falls inside the stated range.
By their numbers in this assay, from the lowest: compounds 3, 1 and 4 (each within the scatter of the next, the first and the last beyond it); then compound 2.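

On the aromatic carbon meta to a carboxy group, 4-methoxyphenyl in place of 3-chlorophenyl gives a 2.2-fold higher number from compound 3 to compound 4 (0.34 log units; beyond the scatter) in this assay. This position therefore responds to an exchange of one aryl group for another, which the earlier step, made on an oxygen, could not show. No measurement shown accounts for the difference between the two groups.

The exchange alters both the substituent and its place on the aryl ring, and the compounds shown do not separate the two. A 4-chlorophenyl group on this carbon would separate them.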